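The source may hold more compounds than are shown below. What is called first, only, known or untested is meant among the compounds shown, and "the series" means these compounds.

The measured compounds:

Compound 1, `COc1ccc(-c2cn(-c3ccc(OC)cc3OC)nn2)cc1`, gives > 10000 nM in a functional assay on MDA-MB-231 cells (Homo sapiens) for cytotoxicity, read by MTT assay; a lower number here means a stronger inhibitor, a higher number a weaker inhibitor; this is a limit of the assay, not a number.
Compound 2, `COc1ccc(-c2cn(-c3ccc(Oc4ccccc4)cc3)nn2)cc1`, gives > 100 nM in this assay; this too is a limit, not a number.
Compound 3, `Nc1ccc(-c2cn(-c3ccc(Oc4ccccc4)cc3)nn2)cc1`, gives > 10000 nM in this assay; again a limit, not a number.

Compound 1 therefore stands only at a limit, (the limit of > 10000 nM in this assay, at which 2 of the 3 values shown sit), and no number is known for it. Among the compounds with values here, the single value at the limit of > 100 nM in this assay, at which 1 of the 3 values shown sits, belongs to compound 2.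

Compound 4, `COc1ccc(-n2cc(-c3ccc(N)cc3)nn2)c(OC)c1`, differs from compound 1 in one place: amino in place of methoxy on an aromatic carbon. The same change has been measured once before, as a step that the two limits leave unreadable from compound 2 to compound 3, but its size cannot be read, both ends being limits of the assay. Nothing measured here points in either direction, and no step beyond the scatter can be justified.

The step that the limit leaves unreadable from compound 1 to compound 4 is therefore expected to be none beyond the scatter, with the result most likely again reported only as a limit. Compound 4 is expected to give about 20000 nM in this assay, within the range 5000 nM to 80000 nM.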

Compound 4, half-maximal inhibitory concentration: > 10000 nM
Compound 4: only a limit was reported (the forecaster's own chance of this, stated with the estimate: 80%); the middle value lies beyond the limit too.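

Compound 1 and compound 4 both stand only at a limit in this assay, so no size can be read for the change from methoxy to amino between them. The compounds shown leave open what number any of them would reach, and whether this change shifts potency at all.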